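The source may report more compounds than this note shows. Statements on the series, on what has been measured and on what is new or still open speak of the compounds shown alone.

Measured in a functional assay on A2780 cells (Homo sapiens) for inhibition, with a stated time of 72 h; on this read-out higher numbers stand for weaker inhibition and lower numbers for stronger inhibition:
- compound 1 `CC(=O)O[C@@]1([C@@H]2/C(C)=C(/O)C(=O)C3=C(C)[C@@H](OC(=O)[C@H](O)[C@H](C=C(C)C)NC(=O)OC(C)(C)C)C[C@@](O)([C@H]2OC(=O)c2cccc(Cl)c2)C3(C)C)CO[C@@H]1CCO`: 4.6 nM
- compound 2 `CC(=O)O[C@@]1([C@@H]2/C(C)=C(/O)C(=O)C3=C(C)[C@@H](OC(=O)[C@H](O)[C@H](CC(C)C)NC(=O)OC(C)(C)C)C[C@@](O)([C@H]2OC(=O)c2cccc(F)c2)C3(C)C)CO[C@@H]1CCO`: 11.1 nM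
- compound 3 `CC(=O)O[C@@]1([C@@H]2/C(C)=C(/O)C(=O)C3=C(C)[C@@H](OC(=O)[C@H](O)[C@H](C=C(C)C)NC(=O)OC(C)(C)C)C[C@@](O)([C@H]2OC(=O)c2cccc(F)c2)C3(C)C)CO[C@@H]1CCO`: 6.1 nM

Compound 3, at 6.1 nM, holds the middle number of the three, but its steps to both others stay within the scatter. Compound 4 `COc1cccc(C(=O)O[C@H]2[C@H]([C@]3(OC(C)=O)CO[C@@H]3CCO)/C(C)=C(/O)C(=O)C3=C(C)[C@@H](OC(=O)[C@H](O)[C@H](C=C(C)C)NC(=O)OC(C)(C)C)C[C@]2(O)C3(C)C)c1` carries methoxy in place of fluoro on an aromatic carbon. Within the data shown here, no measured compound has methoxy there. The closest guide is the swap of fluoro for chloro on an aromatic carbon, a 1.3-fold higher number from compound 1 to compound 3 (0.12 log units; within the scatter). The step of a 1.8-fold lower number from compound 2 to compound 3 (0.26 log units; within the scatter) concerns a change elsewhere, 2-methylprop-1-en-1-yl in place of isobutyl, and is also small. In this assay, no shift beyond the scatter is therefore expected. The expected step is a 1.0-fold lower number from compound 3 to compound 4 (0.01 log units; within the scatter). Compound 4 is estimated at 6 nM, with an expected range of 2.5 nM to 15 nM.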

Compound 4, half-maximal inhibitory concentration: 4.6 nM
The estimate for compound 4 lay 1.3-fold (0.12 log units) above the measured number, and the stated range covers the measured number.
By their numbers in this assay, from the lowest: compounds 1, 4, 3 and 2 (each within the scatter of the next, the first and the last beyond it).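

In this assay the step of a 1.3-fold lower number from compound 3 to compound 4 (0.12 log units; within the scatter) and the step of no change at the digits printed from compound 1 to compound 4 (within the scatter) both stay small, so methoxy, with more heavy atoms than fluoro and a hydrogen-bond acceptor, fits on this aromatic carbon as well as the two halogens do. The earlier compounds had shown only chloro and fluoro here. Nothing available explains why this swap changes so little.

From the compounds shown here alone, whether an amine, a carboxylic acid or a longer chain such as ethoxy on this carbon would stay within the same range remains open. So does whether 3-methoxyphenyl would behave alike with isobutyl in place of 2-methylprop-1-en-1-yl.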